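Shifting the halogen on the aryl ring of compound 3

The compounds below may be only part of what the source reports. "The series", "measured", "known", "first", "only" and "open" are said of these compounds alone.

Compound 3 `CC(=O)OC/C(=C\c1ccc(Cl)cc1)C(=O)c1ccccc1` has the lowest number among the three measured compounds: in a functional assay on HeLa cells (Homo sapiens) for inhibition, read by sulforhodamine B assay, with a stated time of 48 h (on this read-out higher numbers stand for weaker inhibition of growth and lower numbers for stronger inhibition of growth), compound 3 gives 3200 nM. Compound 1 `O=C(/C(=C/c1ccc(Cl)cc1)CCl)c1ccccc1` gives 22000 nM in this assay, and compound 2 `CC(=O)OC/C(=C\C1CCCCC1)C(=O)c1ccccc1` gives 21000 nM. The two measured steps both lead to compound 3: a 6.9-fold lower number from compound 1 to compound 3 (0.84 log units; beyond the scatter), and a 6.6-fold lower number from compound 2 to compound 3 (0.82 log units; beyond the scatter). Compound 4 `CC(=O)OC/C(=C\c1ccccc1Br)C(=O)c1ccccc1` differs from compound 3 in one place: 2-bromophenyl in place of 4-chlorophenyl on a double-bonded chain carbon bound to a double-bonded chain carbon. For the measured compounds named here, neither measured step exchanges one halogenated phenyl for another, so no step directly bears on this change. Going by the values given here, the step from compound 2 to compound 3 shows only that an aryl group at this position gives a lower number than cyclohexyl, and compound 4 keeps an aryl group there. For compound 4 an unchanged number within the scatter, or at most a small rise, is therefore expected, so that the expected step of a 1.4-fold higher number from compound 3 to compound 4 (0.15 log units; within the scatter) stays modest. In this assay compound 4 is estimated at 4500 nM, in a range from 1500 nM to 14000 nM.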

Compound 4, concentration for 50% growth inhibition: 20000 nM
Estimate against measurement, compound 4: 4.4-fold (0.65 log units) below; the measured number lies above the stated range.
By their numbers in this assay, from the lowest: compound 3; then compounds 4, 2 and 1 (each within the scatter of the next).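

In this assay, the change from 4-chlorophenyl to 2-bromophenyl is not a neutral exchange of one halogenated phenyl for another: a 6.3-fold higher number from compound 3 to compound 4 (0.80 log units; beyond the scatter). The earlier advantage of 4-chlorophenyl over cyclohexyl therefore does not extend to every aryl group at this place, since a 1.1-fold lower number from compound 2 to compound 4 (0.02 log units; within the scatter) leaves 2-bromophenyl and cyclohexyl within the scatter of each other, and compound 4 goes against any rule that an aryl group here gives the lower number. No supporting evidence is available to explain this difference.

The step changes both the halogen and its place on the ring, so the compounds shown cannot assign the rise to either one. A 4-bromophenyl or 2-chlorophenyl group would separate the two, while an unsubstituted phenyl group would show how either halogen compares with none.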